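Moving the Bromine Within a Sulfonamide Aryl Group

This account rests on a few compounds, and the source may have more. Where it says the series, first, only, none or still open, it means among the compounds named here.

Compound 1 `CCCCCCC#Cc1ccc(S(=O)(=O)Nc2cccc(-c3csc(NC(C)=O)n3)c2)cc1` carries a heptynyl chain on the ring that sits on its sulfonyl sulfur; in a functional assay on A-375 cells (Homo sapiens) for antiproliferative activity, read by trypan blue exclusion, with a stated time of 48 h, tested at 1 uM (on this read-out lower numbers stand for a stronger effect and higher numbers for a weaker effect at the one concentration tested), compound 1 gives 40.7%. Compound 2 `CC(=O)Nc1nc(-c2cccc(NS(=O)(=O)c3ccc(Br)cc3)c2)cs1` keeps the shared core but carries a 4-bromophenyl on the sulfonyl sulfur instead; in this assay compound 2 is recorded as "not active" (no number reported), with no number attached. Compound 2 therefore stands nowhere on the numerical scale: it can only be placed as lacking a measurable effect at the single concentration used, while compound 1 does show one.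

Compound 3 `CC(=O)Nc1nc(-c2cccc(NS(=O)(=O)c3cccc(Br)c3)c2)cs1` is the unmeasured partner of compound 2. The two hold the same atoms joined differently: 3-bromophenyl in place of 4-bromophenyl on a sulfonyl sulfur. Within the data shown here, no step between two measured compounds is available to gauge what moving a bromine on this ring does, so the expected size of the step in this assay is uncertain; with compound 2 showing no effect, the most likely outcome is a change that stays within the scatter, in no firm direction. Compound 3 is accordingly estimated to give 90%, within a range from 65% to 100%.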

Compound 3, a percentage reported as activity, at one concentration (the size of the read-out at that concentration, not a potency): "not active" (no number reported)
For compound 3 the study gives words and no number; there is nothing to compare the estimate with.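

Compound 2 and compound 3 are both recorded in this assay as not active, without a number, so no step can be read for moving the bromine. No measurement shown here bears on this result. On these data alone, what stays open is whether the 4-bromophenyl of compound 2 and the 3-bromophenyl of compound 3 differ at all in their effect.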